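The source may hold more compounds than are shown below. What is called first, only, known or untested is meant among the compounds shown, and "the series" means these compounds.

Going by the values given here, compound 1 `C=CCOCC(N)C(=O)NCc1ccccc1` is the only compound of the series with a numerical result: in a functional assay on the whole organism (strain NMRI) for inhibition, with Mus musculus as the target, in the formalin test, with a stated time of 30 min (on this read-out lower numbers stand for an effect already at smaller amounts and higher numbers for an effect only at larger amounts of compound), compound 1 gives 75 mg/kg. Compound 2 `CCCC[C@@H](N)C(=O)NCc1ccccc1` reaches only a limit of the assay, > 71 mg/kg in this assay, and this point the limit of > 71 mg/kg in this assay, at which 1 of the 2 values shown sits, adds no number. Compound 3 `CN(C)CC(N)C(=O)NCc1ccccc1` carries dimethylamino in place of allyloxy on a saturated chain carbon, two bonds along the chain from an amine nitrogen and a carbonyl carbon. Among the compounds with values here, no step between measured compounds is known for this kind of change, and the expected step is none beyond the scatter, so a 1.1-fold higher number from compound 1 to compound 3 (0.03 log units; within the scatter) is the estimated change. Compound 3 is estimated at 80 mg/kg in this assay, within 40 mg/kg to 200 mg/kg.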

Compound 3, dose for half-maximal effect: 83 mg/kg
Estimate against measurement, compound 3: 1.0-fold (0.02 log units) below; the measured number falls inside the stated range.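

At the saturated chain carbon, two bonds along the chain from an amine nitrogen and a carbonyl carbon, this assay gives a 1.1-fold higher number from compound 1 to compound 3 (0.04 log units; within the scatter). Dimethylamino and allyloxy are therefore not told apart at this position by this read-out, although the double bond leaves and the heavy-atom count changes. The data shown offer no explanation for this step.

Compound 2 remains a limit of the assay at > 71 mg/kg, not a number. From the compounds shown here alone, whether a carboxylic acid, a morpholine or a longer ether chain at this position would give a step beyond the scatter stays open.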